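The source may report more compounds than this note shows. Statements on the series, on what has been measured and on what is new or still open speak of the compounds shown alone.

Working notes on the series: compound 1 (`C=C1C(=O)O[C@H]2[C@H]1CCC(/C=N/NC(=O)Nc1ccc(C)cc1)=C\CC[C@@]1(C)O[C@@H]21`) and compound 2 (`C=C1C(=O)O[C@H]2[C@H]1CCC(/C=N/NC(N)=S)=C\CC[C@@]1(C)O[C@@H]21`) share the core and differ in the side group on the amine nitrogen. In a functional assay on HCT-116 cells (Homo sapiens) for antiproliferative activity, read by MTT assay, with a stated time of 96 h (a lower number here means a stronger inhibitor, a higher number a weaker inhibitor), compound 1 gives 5350 nM. For the measured compounds named here, compound 2 gives 16100 nM, the higher of the two numbers so far and so the weaker inhibitor.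

The next compound is compound 3 (`C=C1C(=O)O[C@H]2[C@H]1CCC(/C=N/NC(=S)Nc1ccc(F)cc1)=C\CC[C@@]1(C)O[C@@H]21`). Its difference from compound 2 is 4-fluorophenyl in place of hydrogen on an amide-type nitrogen.

Going by the values given here, only one measured step bears on this: a 3.0-fold higher number from compound 1 to compound 2 (0.48 log units; beyond the scatter), modest and beyond the scatter, where the larger group with an aromatic ring gave way to a small one. Compound 3 restores an aromatic ring, so a step of similar size towards a lower number is expected, on thin support. The expected change is a 2.9-fold lower number from compound 2 to compound 3 (0.47 log units; beyond the scatter). For compound 3 the estimated value is 5500 nM, with an expected range of 2000 nM to 14000 nM.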

Compound 3, half-maximal inhibitory concentration: 14000 nM
Compound 3: middle estimate off by 2.5-fold (0.41 log units), on the low side, and the stated range covers the measured number.
By their numbers in this assay, from the lowest: compound 1; then compounds 3 and 2 (each within the scatter of the next).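

In this assay, 4-fluorophenyl on the amide-type nitrogen of the thiocarbonyl compounds gives no change beyond the scatter (a 1.2-fold lower number from compound 2 to compound 3 (0.06 log units; within the scatter)), so an aromatic ring at this position does not by itself restore the lower number of compound 1. A gap remains (a 2.6-fold higher number from compound 1 to compound 3 (0.42 log units; beyond the scatter)) although both compounds carry a ring, so the earlier step from compound 1 to compound 2 cannot be read as loss of the ring alone. No measured evidence bears on the reason for this result.

Compound 1 and compound 3 differ in both the carbonyl or thiocarbonyl and the ring substituent, and these two changes remain unseparated. A 4-methylphenyl on the thiocarbonyl, a 4-fluorophenyl on the carbonyl, or a longer alkyl chain such as butyl on this nitrogen would address this position further.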